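Swapping a Fluorophenyl for a Pyrimidinyl on a Weak Core

A few compounds are considered here, and "the series" means these few. Any claim that something is new, unique, unknown or untested is made for them only; others in the source may bear on it.

Of the compounds shown here, three share one core and have been tested in a functional assay on HL-60 cells (Homo sapiens) for cytotoxicity, read by CellTiter-Blue, with a stated time of 48 h; a lower number here means a stronger inhibitor, a higher number a weaker inhibitor. Compound 1 `CCCCOC(=O)CC1C(C(=O)OCCCC)=C(N)Oc2ccc(-c3cc(OC)cc(OC)c3)cc21` gives 32000 nM. Compound 2 `COc1cc(OC)cc(-c2ccc3c(c2)C(CC(=O)OCC2CO2)C(C(=O)OCC2CO2)=C(N)O3)c1` reaches only a limit of the test, > 80000 nM, and so has no number. That limit, (the limit of > 80000 nM in this assay, at which 1 of the 3 values shown sits), is where one of the three values sits. Compound 3 `CCOC(=O)CC1C(C(=O)OCC)=C(N)Oc2ccc(-c3cccc(F)c3)cc21` gives 76400 nM, the higher of the two numbers that exist; its nearest neighbour is compound 1, whose number is lower by a gap beyond the usual scatter of this assay.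

Compound 4 `CCOC(=O)CC1C(C(=O)OCC)=C(N)Oc2ccc(-c3cncnc3)cc21` has not yet been measured. It differs from compound 3 in one place: pyrimidin-5-yl in place of 3-fluorophenyl on an aromatic carbon. Going by the values given here, no measured pair shows this kind of swap, so there is no step to lean on. All three values sit in a weak range, and nothing among them points to a large gain. The expected step from compound 3 to compound 4 is a 1.1-fold lower number from compound 3 to compound 4 (0.04 log units; within the scatter), small and likely within the scatter or slightly toward a weaker compound. Compound 4 is thus expected to give about 70000 nM, with a range from 25000 nM to 200000 nM, and a fair chance that only a limit is reported.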

Compound 4, half-maximal inhibitory concentration: 37900 nM
Compound 4: the middle estimate sits 1.8-fold (0.27 log units) above what was measured; the measured number falls inside the stated range.
By their numbers in this assay, from the lowest: compounds 1, 4 and 3 (each within the scatter of the next, the first and the last beyond it). At a limit, above all of these: compound 2.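

The swap of pyrimidin-5-yl in place of 3-fluorophenyl on an aromatic carbon of the shared core gives, in this assay, a 2.0-fold lower number from compound 3 to compound 4 (0.30 log units; within the scatter), so the two compounds cannot be told apart in this test. Going by these compounds alone, until now every compound carried a ring of carbon only at this place, so this is the first sign that a ring with 2 hetero atoms and 2 hydrogen-bond acceptors can stand there and leave the number in the same weak range. Nothing measured here gives a reason for the size of this step.

Open, going by these compounds, is how a pyridinyl ring, or a ring bearing an amine or a carboxylic acid, would read at this same place. Also open, on these data alone, is whether the same swap would give a similar step on the butyl esters of compound 1.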